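A few compounds are considered here, and "the series" means these few. Any claim that something is new, unique, unknown or untested is made for them only; others in the source may bear on it.

In a functional assay on NCI-H460 cells (Homo sapiens) for inhibition, read by sulforhodamine B assay, with a stated time of 48 h (a higher number here means a weaker inhibitor of growth, a lower number a stronger inhibitor of growth), compound 1 `O=C(NNC(=O)c1ccc2[nH]c(-c3ccc([N+](=O)[O-])o3)nc2c1)c1ccccc1` gives 62.5 ug/mL. Compound 2 `COc1cccc(C(=O)NNC(=O)c2ccc3[nH]c(-c4ccc([N+](=O)[O-])o4)nc3c2)c1` has the same core and adds a methoxy group, and compound 2 gives 62.5 ug/mL. On these numbers it stands level with compound 1, and neither can be ranked above the other.

Compound 3 `O=C(NNC(=O)c1ccc2[nH]c(-c3ccc([N+](=O)[O-])o3)nc2c1)c1cccc(Oc2ccccc2)c1` differs from compound 2 in one place: phenyl in place of methyl on an oxygen on an aromatic ring. Put simply, methoxy becomes phenoxy, with phenyl in place of methyl on an oxygen on an aromatic ring.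

Among the compounds with values here, only one measured step bears on this change, the one that introduced the methoxy group, and it shows no change at the digits printed from compound 1 to compound 2 (within the scatter). Within the data shown here, that step is a weak guide, since no measured compound carries a phenyl group at this oxygen. The data therefore fix no direction, and no shift beyond the scatter is expected in this assay, although a real shift either way remains possible. The expected step is a 1.3-fold lower number from compound 2 to compound 3 (0.10 log units; within the scatter). For compound 3 the estimated value is 50 ug/mL, with an expected range of 15 ug/mL to 125 ug/mL.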

Compound 3, concentration for 50% growth inhibition: > 7.8 ug/mL
Compound 3: only a limit was reported; the forecaster's own chance of this, stated with the estimate: 15%; the middle value lies beyond the limit too.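

In this assay compound 3 carries only a limit, > 7.8 ug/mL, and not a number, so its steps from compound 1 and from compound 2 cannot be read. The compounds shown leave open whether phenoxy in place of methoxy shifts the result in this assay at all, and in which direction.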